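The source may report more compounds than this note shows. Statements on the series, on what has been measured and on what is new or still open speak of the compounds shown alone.

Of the compounds shown here, two have so far been measured in a functional assay on MCF7 cells (Homo sapiens) for antiproliferative activity; a higher number here means a weaker inhibitor, a lower number a stronger inhibitor. Compound 1 `COc1cc(Cc2nc3c(N)ncnc3n2CC2CC2)cc(OC)c1OC` gives 75900 nM in this assay, the higher of the two numbers. Compound 2 `C=CCCn1c(Cc2cc(OC)c(OC)c(OC)c2)nc2c(N)nc(F)nc21` gives 33100 nM in this assay, a lower number than that of compound 1, and the gap between the two lies beyond the usual scatter of this kind of measurement. Compound 3 `COc1cc(Cc2nc3c(N)ncnc3n2CC2CCC2)cc(OC)c1OC` has not yet been measured. It differs from compound 1 in one place: cyclobutyl in place of cyclopropyl on a saturated chain carbon bound to an aromatic nitrogen. Within the data shown here, no pair of measured compounds shows this change on its own, so there is no measured step to lean on. Since the change leaves everything else in compound 1 untouched, the step of a 1.3-fold lower number from compound 1 to compound 3 (0.10 log units; within the scatter) is expected to be small, at most a slight move toward a lower number, and may not reach beyond the scatter. Compound 3 is therefore expected to give about 60000 nM in this assay, with a range from 25000 nM to 150000 nM.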

Compound 3, half-maximal inhibitory concentration: 45700 nM
For compound 3 the middle estimate is 1.3-fold (0.12 log units) above the measured one, and the stated range covers the measured number.
By their numbers in this assay, from the lowest: compounds 2, 3 and 1 (each within the scatter of the next, the first and the last beyond it).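

Among these compounds, at this place, on a saturated chain carbon bound to an aromatic nitrogen, compound 3 gives the first reading of a single change in this assay: cyclobutyl in place of cyclopropyl gives a 1.7-fold lower number from compound 1 to compound 3 (0.22 log units; within the scatter). As far as this assay can tell, then, the exchange of these two rings leaves the number where it was, and the antiproliferative effect at this place tolerates either ring. Nothing measured here offers a reason for this result.

Going by these compounds, whether a phenyl ring, or a chain ending in an amine or a carboxylic acid, would carry the number beyond the scatter at this place stays open. Compound 2 differs from compound 1 in more than one place, so it cannot show what any one of its changes does.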